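Epoxide to oxolane: cytotoxicity notes on compound 4

This account rests on a few compounds, and the source may have more. Where it says the series, first, only, none or still open, it means among the compounds named here.

Measured in a functional assay on MDCK cells (Canis lupus familiaris) for inhibition; a lower number here means that less compound is tolerated, a higher number that more compound is tolerated:
- compound 1 `Cn1c(CC2(C)CO2)cc(=O)n(C)c1=O`: 4000 nM
- compound 2 `Cn1c(C[C@]2(C)CCCO2)cc(=O)n(C)c1=O`: 1380000 nM
- compound 3 `CC1O[C@]1(C)Cc1cc(=O)n(C)c(OC2CCCCC2)n1`: > 342000 nM

Compound 3 gives no number, only a limit of the assay, > 342000 nM. Compound 4 `Cn1c(OC2CCCCC2)nc(CC2(C)CCCO2)cc1=O` differs from compound 3 in one place: a group of 6 heavy atoms (5 carbon, 1 oxygen; one five-membered non-aromatic ring with 1 hetero atom) in place of a group of 5 heavy atoms (4 carbon, 1 oxygen; one three-membered non-aromatic ring with 1 hetero atom), on a saturated chain carbon bound to an aromatic carbon. Among the measured compounds shown here, no measured step covers this change. Compound 2 also carries the 2-methyloxolan-2-yl group and gives 1380000 nM, a higher value than compound 1 at 4000 nM. With compound 2 at 1380000 nM, no step beyond the usual scatter is expected in this assay, and any shift is expected to be upward. The expected change is a step that the limit leaves unreadable from compound 3 to compound 4. For compound 4 the estimate is 600000 nM, with an expected range of 200000 nM to 1800000 nM.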

Compound 4, half-maximal cytotoxic concentration: 816000 nM
For compound 4 the middle estimate is 1.4-fold (0.13 log units) below the measured one, within the range that was stated.
By their numbers in this assay, from the lowest: compound 1; then compounds 4 and 2 (each within the scatter of the next).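

No new step can be read between compound 3 and compound 4, because compound 3 gives only a limit of the assay: the limit of > 342000 nM in this assay, at which 1 of the 4 values shown sits.

The compounds shown leave open how large a shift the 2-methyloxolan-2-yl group brings on the core of compound 3.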